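From isopropylcarbonyl to methoxymethyl on compound 2

This account rests on a few compounds, and the source may have more. Where it says the series, first, only, none or still open, it means among the compounds named here.

In a functional assay on SW480 cells (Homo sapiens) for antiproliferative activity, read by MTT assay, with a stated time of 48 h (on this read-out lower numbers stand for stronger inhibition and higher numbers for weaker inhibition), compound 1 (`CSC(=S)OC/C1=C/C[C@](C)(CCC=C(C)C)/C=C/[C@@H](OC(=O)C=C(C)C)[C@](C)(O)/C=C/C1=O`) gives 390 nM and compound 2 (`CC(C)=CCC[C@]1(C)/C=C/[C@@H](OC(=O)C(C)C)[C@](C)(O)/C=C/C(=O)/C(CO)=C\C1`) gives 8510 nM as the higher of the two numbers, which marks the weaker inhibition. Compound 3 (`COCO[C@@H]1/C=C/[C@@](C)(CCC=C(C)C)C/C=C(/CO)C(=O)/C=C/[C@@]1(C)O`) has methoxymethyl in place of isopropylcarbonyl on an oxygen on a saturated carbon. Going by the values given here, no measured pair shows this change, so in this assay only a small step towards higher numbers is expected, perhaps none beyond the scatter. The estimated size is a 1.4-fold higher number from compound 2 to compound 3 (0.15 log units; within the scatter) in that direction. Compound 3 is expected at 12000 nM with 4000 nM to 35000 nM as its estimated range.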

Compound 3, half-maximal inhibitory concentration: > 40000 nM
Compound 3 was reported as a limit (the forecaster's own chance of this, stated with the estimate: 15%); middle value at least 3.3-fold (0.52 log units) away from the limit.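

Methoxymethyl in place of isopropylcarbonyl on an oxygen on a saturated carbon gives an at least 4.7-fold higher number from compound 2 to compound 3 (0.67 log units; beyond the scatter) in this assay, the only measured step at this position, and it runs towards weaker inhibition. In this assay compound 3 gives > 40000 nM, which is a limit and not a number. The step therefore has only a lower bound: the limit of > 40000 nM in this assay, at which 1 of the 3 values shown sits.

On these data alone, it remains open whether a free hydroxyl, an acetyl or a benzoyl group on this oxygen would stay near compound 2. As far as these compounds go, whether a longer alkyl ether would behave like methoxymethyl also remains open.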